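A quinolin-7-yl swap on a saturated ring carbon

The source may hold more compounds than are shown below. What is called first, only, known or untested is meant among the compounds shown, and "the series" means these compounds.

Measured in a functional assay on KB 3-1 cells (Homo sapiens), with a stated time of 72 h; a lower number here means a stronger inhibitor, a higher number a weaker inhibitor:
Compound 1 `Cc1nc2cc([C@@H]3C[C@@H]4O[C@]4(C)CCC[C@H](C)[C@H](O)[C@@H](C)C(=O)C(C)(C)[C@@H](O)CC(=O)O3)ccc2s1`: 0.13 nM
Compound 2 `C[C@H]1CCC[C@@]2(C)O[C@H]2C[C@@H](c2ccc3c(c2)ncn3C)OC(=O)C[C@H](O)C(C)(C)C(=O)[C@H](C)[C@H]1O`: 0.13 nM
Compound 3 `Cc1nc2cc([C@@H]3C[C@@H]4O[C@]4(C)CCC[C@H](C)[C@H](O)[C@@H](C)C(=O)C(C)(C)[C@@H](O)CC(=O)O3)ccc2n1C`: 0.14 nM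

Compound 3, at 0.14 nM, lies within the scatter of both other compounds. Compound 4 `C[C@H]1CCC[C@@]2(C)O[C@H]2C[C@@H](c2ccc3cccnc3c2)OC(=O)C[C@H](O)C(C)(C)C(=O)[C@H](C)[C@H]1O` differs from it by one change: a group of 10 heavy atoms (9 carbon, 1 nitrogen; one six-membered aromatic ring of carbon only, one six-membered aromatic ring with 1 hetero atom) in place of a group of 11 heavy atoms (9 carbon, 2 nitrogen; one five-membered aromatic ring with 2 hetero atoms, one six-membered aromatic ring of carbon only), on a saturated ring carbon. Three measured steps exchange or alter the same fused aromatic group, and all stay within the scatter: no change at the digits printed from compound 1 to compound 2 (within the scatter), a 1.1-fold higher number from compound 1 to compound 3 (0.03 log units; within the scatter) and a 1.1-fold higher number from compound 2 to compound 3 (0.03 log units; within the scatter). For the measured compounds named here, none of the measured compounds carries quinolin-7-yl, so the data offer no direct precedent for it. On those three steps, no shift beyond the scatter is expected, and the estimated step is a 1.4-fold higher number from compound 3 to compound 4 (0.15 log units; within the scatter). For compound 4 the expected value is 0.2 nM, with an estimated range from 0.08 nM to 0.5 nM.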

Compound 4, half-maximal inhibitory concentration: 0.11 nM
Compound 4: middle estimate off by 1.8-fold (0.26 log units), on the high side, and the stated range covers the measured number.
By their numbers in this assay, from the lowest: compounds 4, 1, 2 and 3 (each within the scatter of the next).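

Quinolin-7-yl, with its nitrogen in a six-membered aromatic ring, stays within the scatter of all three earlier groups on this saturated ring carbon next to the ring oxygen in this assay (a 1.3-fold lower number from compound 3 to compound 4 (0.10 log units; within the scatter); a 1.2-fold lower number from compound 2 to compound 4 (0.07 log units; within the scatter); a 1.2-fold lower number from compound 1 to compound 4 (0.07 log units; within the scatter)). Across compounds 1 to 4, this position therefore accepts this six-membered aromatic ring as well as the five-membered aromatic rings with 2 hetero atoms. Nothing available accounts for why these groups read alike.

From the compounds shown here alone, whether a single phenyl ring, or a quinolin-7-yl bearing an amine or a carboxylic acid, would stay within the same scatter remains open.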